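Anilide series: antiproliferative read-out in a mouse model

The source may report more compounds than this note shows. Statements on the series, on what has been measured and on what is new or still open speak of the compounds shown alone.

Measured so far:
compound 1 `Nc1ccccc1NC(=O)CCCNCC(=O)Nc1ccc(Cl)cc1`: 75%
compound 2 `Nc1ccccc1NC(=O)c1ccc(NCC(=O)Nc2ccc([N+](=O)[O-])cc2)cc1`: 77.5%

In a functional assay on the whole organism (Ehrlich cells, Mus musculus) for antiproliferative activity, with a stated time of 24 h, at a dose of 0.2 mmol/kg by the intraperitoneal route (a lower number here means less inhibition, a higher number more inhibition at the dose given (going by the name of the read-out)), compound 1 gives 75%. Compound 2 gives 77.5% in this assay, and the two numbers lie within the usual scatter of each other, so compound 1 cannot be set apart from compound 2 on this read-out. Going by the values given here, no pair of measured compounds differs in one place only, so no single step is available for comparison.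

Compound 3 `Nc1ccccc1NC(=O)CCCNCC(=O)Nc1cc(Cl)ccc1Cl` is the next compound to go into this assay. Relative to compound 1 the change is 2,5-dichlorophenyl in place of 4-chlorophenyl on an amide-type nitrogen. Nothing in the measured pairs speaks to this particular change. The step of no change at the digits printed from compound 1 to compound 3 (within the scatter) is therefore expected to stay within the scatter, in no particular direction. Compound 3 is estimated at 75%, with a range from 55% to 90%.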

Compound 3, a percentage reported as inhibition, in the whole organism at one dose (the size of the read-out at that dose, not a potency): 50.9%
Beside the measured number, compound 3's estimate is 24.1 percentage points above it; measured number outside the range, below it.
By their numbers in this assay, from the lowest: compound 3; then compounds 1 and 2 (each within the scatter of the next).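

In this assay, going by these compounds alone, the group on the amide-type nitrogen proves to be a position that matters: 2,5-dichlorophenyl in place of 4-chlorophenyl gives a number 24.1 percentage points lower from compound 1 to compound 3 (beyond the scatter) and is the only single-place comparison so far. Adding one chlorine to this phenyl group, with the rest of the core of compound 1 unchanged, is therefore enough to move the read-out beyond the scatter, and here the direction is towards less inhibition at the dose given. No supporting data on hand explain this loss.

This single step changes both the number and the placement of the chlorines, so it leaves open which of the two matters. Also open, on these data alone, is how a plain phenyl or a methoxyphenyl on the same nitrogen, or a longer chain in the linker, would read out.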